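Swapping the aryl group on the dihydropyrimidine core

A few compounds are considered here, and "the series" means these few. Any claim that something is new, unique, unknown or untested is made for them only; others in the source may bear on it.

Compound 1 `CCOC(=O)C1=C(C)N/C(=N\C#N)NC1c1cccs1` carries a thiophen-2-yl group on a saturated ring carbon of the shared core. In an assay on cells for displacement of a labelled ligand from adenosine receptor A1 (Homo sapiens), with a stated time of 60 min, tested at 1 uM (a higher number here means more inhibition at the concentration tested (going by the name of the read-out), a lower number less inhibition), compound 1 gives 26%. Compound 2 `CCOC(=O)C1=C(C)N/C(=N\C#N)NC1c1ccccc1` carries a phenyl group at the same position, and in this assay compound 2 gives 18%. Going by the values given here, of the two numbers so far, compound 2 stands lowest, but its nearest neighbour is compound 1, and the step of a number 8 percentage points lower from compound 1 to compound 2 (within the scatter) lies within the scatter, so no real order between them can be read.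

Compound 3 `CCOC(=O)C1=C(C)N/C(=N\C#N)NC1c1ccoc1` is not yet measured. It differs from compound 2 in one place: furan-3-yl in place of phenyl on a saturated ring carbon. Among the compounds with values here, the only measured step that bears on this change is the exchange of one aromatic ring for another at the same saturated ring carbon, a number 8 percentage points lower from compound 1 to compound 2 (within the scatter), which produced no movement beyond the scatter. An exchange of phenyl for a five-membered ring is therefore expected to move this assay little, in either direction, with the step of a number 4 percentage points higher from compound 2 to compound 3 (within the scatter) expected to stay within the scatter. For compound 3 the expected value in this assay is 22%, with a range of 8% to 38%.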

Compound 3, a percentage reported as inhibition, at one concentration (the size of the read-out at that concentration, not a potency): 28%
Compound 3: the middle estimate sits 6 percentage points below what was measured; the measured number falls inside the stated range.
By their numbers in this assay, from the lowest: compounds 2, 1 and 3 (each within the scatter of the next).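

With furan-3-yl on the saturated ring carbon, the position has now carried three different aromatic rings, and the exchange of the six-membered ring of carbon only for a five-membered ring with an oxygen gives a number 10 percentage points higher from compound 2 to compound 3 (within the scatter) in this assay. The exchange between the two five-membered rings, furan-3-yl for thiophen-2-yl, gives a number 2 percentage points higher from compound 1 to compound 3 (within the scatter), so the two rings cannot be told apart here, and together with the earlier step this means that no order can be read among the three compounds, which all sit at a modest reading at the single concentration tested. No data are available to explain why these three rings read alike.

As far as these compounds go, what remains open is whether this position responds at all to a group of a different kind, such as a cyclohexyl ring, a longer alkyl chain, or a phenyl ring carrying an amine or a carboxylic acid. With readings at one concentration only, the potency of these compounds also stays unknown, and small real differences among them would stay hidden within the scatter.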